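A few compounds are considered here, and "the series" means these few. Any claim that something is new, unique, unknown or untested is made for them only; others in the source may bear on it.

Measured so far in a functional assay on THP-1 cells (Homo sapiens); a lower number here means a stronger inhibitor, a higher number a weaker inhibitor:
Compound 1 `CCSC[C@@](O)([C@@H](Nc1cccc2nc(C)ccc12)c1ccc(C)cc1)C(F)(F)F` gives 2.51 nM.
Compound 2 `CCSC[C@@](O)([C@@H](Nc1cccc2nc(C)ccc12)c1ccc(F)cc1OC)C(F)(F)F` gives 5.01 nM.
Compound 3 `CCSC[C@@](O)([C@@H](Nc1cccc2nc(C)ccc12)c1ccc(OC)cc1F)C(F)(F)F` gives 5.01 nM.

Compound 1 shows the lowest number of the three, yet its steps to compound 2 and compound 3, a 2.0-fold higher number from compound 1 to compound 2 (0.30 log units; within the scatter) and a 2.0-fold higher number from compound 1 to compound 3 (0.30 log units; within the scatter), both lie within the scatter, so no ranking follows. Compound 4 `CCSC[C@@](O)([C@@H](Nc1cccc2nc(C)ccc12)c1ccc(Cl)c(F)c1OC)C(F)(F)F` is not yet measured. It differs from compound 1 in one place: 4-chloro-3-fluoro-2-methoxyphenyl in place of 4-methylphenyl on a saturated chain carbon bound to a nitrogen on an aromatic ring and a saturated chain carbon. The two measured steps that bear on this each replaced the 4-methylphenyl with a phenyl carrying fluoro and methoxy, and each moved the number only slightly upward. Among the measured compounds shown here, compound 4 adds a chloro as well, for which no step exists. A small upward step is therefore expected in this assay: a 2.0-fold higher number from compound 1 to compound 4 (0.30 log units; within the scatter). Compound 4 is estimated at 5 nM, within a range from 2 nM to 13 nM.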

Compound 4, half-maximal inhibitory concentration: 1.59 nM
For compound 4 the middle estimate is 3.1-fold (0.50 log units) above the measured one; measured number outside the range, below it.
By their numbers in this assay, from the lowest: compounds 4, 1, 2 and 3 (each within the scatter of the next, the first and the last beyond it).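

In this assay, among the compounds shown here, the 4-chloro-3-fluoro-2-methoxyphenyl group gives the first steps at this position that lie beyond the scatter, a 3.2-fold lower number from compound 3 to compound 4 (0.50 log units; beyond the scatter) and a 3.2-fold lower number from compound 2 to compound 4 (0.50 log units; beyond the scatter), so adding chloro can matter here. Against the 4-methylphenyl, a 1.6-fold lower number from compound 1 to compound 4 (0.20 log units; within the scatter) stays within the scatter, so the larger group is tolerated but not shown to be better. No available measurement explains these steps.

From the compounds shown here alone, it remains open whether chloro alone accounts for the difference, since fluoro also moves between these compounds. Going by these compounds, how an amine or a carboxylic acid on this phenyl ring would behave also remains unknown.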